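This account rests on a few compounds, and the source may have more. Where it says the series, first, only, none or still open, it means among the compounds named here.

Within the data shown here, in an ADME assay on cells (Bos taurus) for cytotoxicity (on this read-out lower numbers stand for higher toxicity in this test and higher numbers for lower toxicity in this test), compound 1 `Cc1cn([C@H]2C[C@H](OC3Sc4ccccc4S3)[C@@H](CO)O2)c(=O)[nH]c1=O` gives 72400 nM, the only exact number so far. Compound 2 `CSc1ccccc1SCO[C@H]1C[C@H](n2ccc(N)nc2=O)O[C@@H]1CO` gives only a limit of the assay, > 100000 nM. Compound 3 `Cc1cn([C@H]2C[C@H](OC3Sc4ccccc4S3)[C@@H](C)O2)c(=O)[nH]c1=O` keeps the core of compound 1 and changes one group, hydroxymethyl to methyl: hydrogen in place of hydroxy on a saturated chain carbon bound to a saturated ring carbon. In other words, hydrogen stands in place of hydroxy on a saturated chain carbon bound to a saturated ring carbon. Among the measured compounds shown here, no measured pair shows what such a change does, so no step beyond the usual scatter is expected in this assay. For compound 3 the estimated value is 85000 nM, with an expected range of 40000 nM to 130000 nM.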

Compound 3, half-maximal cytotoxic concentration: 81300 nM
Compound 3: the middle estimate sits 1.0-fold (0.02 log units) above what was measured; measured number inside the range.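

In this assay, the first measured pair shows that methyl can stand in for hydroxymethyl at this place on the shared core, with a 1.1-fold higher number from compound 1 to compound 3 (0.05 log units; within the scatter). The hydroxy, with its hydrogen-bond donor and acceptor, is therefore not needed here to hold this read-out where it is. Both compounds give exact numbers, but the scale has a ceiling close by: the limit of > 100000 nM in this assay, at which 1 of the 3 values shown sits.

Going by these compounds, whether an amine, a carboxylic acid or a longer chain at this place would also leave the read-out unmoved stays open. So does whether the same change behaves alike on a different core.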